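Enol and Nitro Variants of the Hydroxyphenyl Dienone Series

The source may report more compounds than this note shows. Statements on the series, on what has been measured and on what is new or still open speak of the compounds shown alone.

Measured so far:
- compound 1 `COc1ccc(/C=C/C=C/C(=O)c2ccccc2O)cc1`: 40%
- compound 2 `O=C(/C=C(O)/C=C/c1ccc([N+](=O)[O-])cc1)c1ccccc1O`: "not active" (no number reported)
- compound 3 `O=C(/C=C/C=C/c1ccccc1)c1cc(Cl)ccc1O`: "not active" (no number reported)

All three were tested in an in vitro assay on cells for inhibition of Amine oxidase [flavin-containing] A (Homo sapiens), read by Amplex Red, with a stated time of 15 min, tested at 100 uM; on this read-out lower numbers stand for less inhibition and higher numbers for more inhibition at the one concentration tested (going by the name of the read-out). Compound 1 gives 40% there. For compound 2 the read-out is reported only as "not active" (no number reported), without a number; compound 3 is in the same position, reported as "not active" (no number reported). Among the compounds with values here, compound 2 therefore stands among the entries that carry no single number, and no step between two measured compounds differing in one place is available in this set.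

The next compound, compound 4 `O=C(/C=C(O)/C=C/c1ccccc1)c1ccccc1O`, is not yet measured. It differs from compound 2 by hydrogen in place of nitro on an aromatic carbon. Within the data shown here, no measured pair shows what this change does in this assay; the only numbered entry, compound 1, carries a different core and a methoxy group and gives a modest read-out. Among the measured compounds shown here, with compound 2 reported as inactive and no comparable step to lean on, a move from compound 2 to compound 4 is expected to be no larger than the scatter in this assay, with a weak read-out remaining the most likely outcome. Compound 4 is estimated to give 20%, with an expected range from 0% to 45%.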

Compound 4, a percentage reported as inhibition, at one concentration (the size of the read-out at that concentration, not a potency): "not active" (no number reported)
No number was reported for compound 4, and the estimate cannot be compared.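

Compound 2 and compound 4 both stand without a number in this assay, so no step can be read for hydrogen in place of nitro. No available evidence bears on this result. The compounds shown leave open whether exchanging nitro for hydrogen changes the read-out at all, since neither compound has a numerical value.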